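The source may hold more compounds than are shown below. What is called first, only, known or untested is meant among the compounds shown, and "the series" means these compounds.

In a functional assay on MGC-803 cells (Homo sapiens) for inhibition, read by sulforhodamine B assay (a lower number here means a stronger inhibitor, a higher number a weaker inhibitor), compound 1 (`O=C1C=C(NCc2ccccc2)C(=O)c2c1nc1n2[C@H]2OC[C@@H](O)[C@H]2OC1`) gives 2670 nM as the higher of the two true numbers in this small set. Compound 2 (`CCc1ccc(NC2=CC(=O)c3c(nc4n3[C@H]3OC[C@@H](O)[C@H]3OC4)C2=O)cc1`) gives a lower 1110 nM with (4-ethylphenyl)amino on the shared core. Compound 3 (`O=C1C(N2CCCCC2)=CC(=O)c2c1nc1n2[C@H]2OC[C@@H](O)[C@H]2OC1`) reads > 4000 nM and this is a limit of the assay, not a number. Among the compounds with values here, compound 4 (`COc1ccccc1NC1=CC(=O)c2nc3n(c2C1=O)[C@H]1OC[C@@H](O)[C@H]1OC3`) is still unmeasured and has 2-methoxyphenyl in place of benzyl on an amine nitrogen as its one change. Within the data shown here, the single measured step, an at least 3.6-fold higher number from compound 2 to compound 3 (0.55 log units; beyond the scatter) in this assay, lies beyond the scatter but ends at a limit and swaps a different group, so it bears only loosely. Compound 4 resembles compound 2 (1110 nM in this assay) in having a phenyl ring directly on the amine nitrogen, which points to a number closer to that one. The expected step (a 1.9-fold lower number from compound 1 to compound 4 (0.28 log units; within the scatter) in this assay) is therefore toward a lower number, of a size close to the scatter. Compound 4 is estimated at 1400 nM in this assay, with an expected range of 600 nM to 3500 nM around that figure.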

Compound 4, half-maximal inhibitory concentration: 1630 nM
For compound 4 the middle estimate is 1.2-fold (0.07 log units) below the measured one; the measured number falls inside the stated range.
By their numbers in this assay, from the lowest: compounds 2, 4 and 1 (each within the scatter of the next, the first and the last beyond it). At a limit, above all of these: compound 3.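

In this assay, 2-methoxyphenyl in place of benzyl on an amine nitrogen gives a 1.6-fold lower number from compound 1 to compound 4 (0.21 log units; within the scatter), so compound 1 and compound 4 cannot be told apart at this position. Within the data shown here, until now the only step in the set ended at a limit of the assay, that of compound 3, whereas this one has a true number at both ends and shows that this exchange of aromatic groups leaves the reading within the scatter. Nothing given here accounts for this step.

As far as these compounds go, compounds 1, 2 and 4 all carry a six-membered aromatic ring on the amine nitrogen, so it remains open how a simple alkyl chain there would read. Also open, from the compounds shown here alone, is whether an amine or a carboxylic acid on that ring would move the number beyond the scatter.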